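The compounds below may be only part of what the source reports. "The series", "measured", "known", "first", "only" and "open" are said of these compounds alone.

Within the data shown here, the two compounds measured so far share one core. Compound 1, `Fc1ccc(-c2[nH]c3cc(F)ccc3c2Cn2ccnc2)cc1`, carries a fluoro group on the six-membered ring of the fused system, and in an assay on isolated protein for inhibition of Aromatase (Homo sapiens), read by ELISA, using NADPH, with a stated time of 24 h (on this read-out higher numbers stand for weaker inhibition and lower numbers for stronger inhibition), compound 1 gives 51.2 nM. Compound 2, `Fc1ccc(-c2[nH]c3cc(Cl)ccc3c2Cn2ccnc2)cc1`, carries chloro in the same place, and in this assay compound 2 gives 32.3 nM. Among the measured compounds shown here, the single measured step, a 1.6-fold lower number from compound 1 to compound 2 (0.20 log units; within the scatter), is too small to tell the two apart. For the measured compounds named here, compound 2 therefore stands beside compound 1, the only other measured compound, at a distance within the scatter.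

Compound 3, `COc1ccc2c(Cn3ccnc3)c(-c3ccc(F)cc3)[nH]c2c1`, differs from compound 2 at that same place: methoxy in place of chloro on an aromatic carbon. Going by the values given here, the only step that bears on this position is a 1.6-fold lower number from compound 1 to compound 2 (0.20 log units; within the scatter), which shows that swapping one halogen for another there left the number essentially unchanged. Nothing measured shows how methoxy behaves at this position, so the expectation for compound 3 is a step no larger than the scatter, a 1.4-fold higher number from compound 2 to compound 3 (0.14 log units; within the scatter), with a wide range allowed for the missing information. Compound 3 is estimated at 45 nM, between 15 nM and 140 nM.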

Compound 3, half-maximal inhibitory concentration: 109 nM
Compound 3: middle estimate off by 2.4-fold (0.38 log units), on the low side, within the range that was stated.
By their numbers in this assay, from the lowest: compounds 2 and 1 (each within the scatter of the next); then compound 3.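

At this position on the shared core, replacing a halogen with methoxy has an effect that can be read: in this assay the change from chloro gives a 3.4-fold higher number from compound 2 to compound 3 (0.53 log units; beyond the scatter), and the change from fluoro gives a 2.1-fold higher number from compound 1 to compound 3 (0.33 log units; beyond the scatter). The chloro and fluoro compounds alone showed no difference beyond the scatter, whereas these modest steps show that the number does respond to the group placed here, with compound 3 giving the weakest inhibition of the three. Methoxy brings two heavy atoms and a hydrogen-bond acceptor where chloro brings one heavy atom and no acceptor, but no measurement here separates those differences or gives a reason for the rise.

The compounds shown leave open how an amine, a nitrile or a longer chain such as ethoxy would behave at this same position, so one methoxy compound cannot show a trend across groups. They also leave open whether methoxy would give a step of similar size if the other fluoro group on the shared core were replaced by a different group.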